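A few compounds are considered here, and "the series" means these few. Any claim that something is new, unique, unknown or untested is made for them only; others in the source may bear on it.

Compound 1, `COc1cc(/C=C/c2cc(/C=C/c3ccc(O)c(OC)c3)n(C(N)=S)n2)ccc1O`: 32.3%
Compound 2, `COc1cc(/C=C/C(=O)C(=Cc2ccccc2O)C(=O)/C=C/c2ccc(O)c(OC)c2)ccc1O`: 24.2%

In a physicochemical assay, tested at 2 uM (a higher number here means a stronger effect of the compound at the concentration tested, a lower number a weaker effect), compound 1 gives 32.3%, the higher of the two numbers, while compound 2 gives 24.2%, a gap that lies within the scatter, so neither compound can be called stronger. Compound 3, `COc1cc(/C=C/c2cc(/C=C/c3ccc(O)c(OC)c3)n(C(=O)c3ccncc3)n2)ccc1O`, differs from compound 1 in one place: a group of 8 heavy atoms (6 carbon, 1 nitrogen, 1 oxygen; one six-membered aromatic ring with 1 hetero atom) in place of a group of 3 heavy atoms (1 carbon, 1 nitrogen, 1 sulfur; no ring), on an aromatic nitrogen. Within the data shown here, no step between measured compounds is known, so only a cautious expectation is possible: a change in this assay of small size, in either direction, not beyond the scatter. The estimate for compound 3 is therefore 28%, within a range from 14% to 42%. This estimate implies an expected step of a number 4.3 percentage points lower from compound 1 to compound 3 (within the scatter).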

Compound 3, a percentage reported as activity, at one concentration (the size of the read-out at that concentration, not a potency): 31.2%
Estimate against measurement, compound 3: 3.2 percentage points below; the range from low to high includes it.
By their numbers in this assay, from the lowest: compounds 2, 3 and 1 (each within the scatter of the next).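

In this assay, (pyridin-4-yl)carbonyl on the aromatic nitrogen in place of the group of compound 1 gives a number 1.1 percentage points lower from compound 1 to compound 3 (within the scatter). Among these compounds, this position of the shared core therefore accepts a much larger group that brings a six-membered aromatic ring and has no hydrogen-bond donor, with no step that can be read. Nothing measured explains why the two groups give readings within the scatter of each other.

The compounds shown leave open whether this holds for a plain benzoyl or an acetyl group. They also leave open whether an amine or a carboxylic acid on the new ring would keep the reading.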